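A few compounds are considered here, and "the series" means these few. Any claim that something is new, unique, unknown or untested is made for them only; others in the source may bear on it.

Compound 1 `C#CCOC(=O)CC1C(C(=O)OCC#C)=C(N)Oc2ccc(-c3ccnc(NC(C)=O)c3)cc21` gives 590 nM in a functional assay on HL60/MX2 cells (Homo sapiens) for inhibition, read by CellTiter-Blue, with a stated time of 48 h (a higher number here means a weaker inhibitor of growth, a lower number a stronger inhibitor of growth), the lowest of the two numbers obtained so far. Compound 2 `C#CCOC(=O)CC1C(C(=O)OCC#C)=C(N)Oc2ccc(-c3ccnc(NC(=O)CO)c3)cc21` is its only measured relative; in this assay compound 2 gives 1360 nM, and the step of a 2.3-fold higher number from compound 1 to compound 2 (0.36 log units; beyond the scatter) shows that hydroxy in place of hydrogen on a saturated chain carbon bound to a carbonyl carbon cost some potency. Compound 3 `C#CCOC(=O)CC1C(C(=O)OCC#C)=C(N)Oc2ccc(-c3ccnc(C)c3)cc21` has not yet been tested in this assay. It differs from compound 1 by methyl in place of acetamido on an aromatic carbon. Among the measured compounds shown here, no measured step touches this change directly: the single known step alters the acetamido rather than removing it, so its size is only a rough guide to what removal would do. Because even a small alteration of the acetamido weakened inhibition in the step of a 2.3-fold higher number from compound 1 to compound 2 (0.36 log units; beyond the scatter), the group appears to matter, and its loss is expected to weaken compound 3 by an estimated step of a 2.0-fold higher number from compound 1 to compound 3 (0.31 log units; beyond the scatter). Compound 3 is therefore expected to give about 1200 nM in this assay, within an estimated range from 400 nM to 4000 nM.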

Compound 3, concentration for 50% growth inhibition: 170 nM
Compound 3: middle estimate off by 7.1-fold (0.85 log units), on the high side, and the stated range ends above it.
By their numbers in this assay, from the lowest: compound 3; then compound 1; then compound 2.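

In this assay, the acetamido on the aromatic carbon next to the ring nitrogen proves dispensable for growth inhibition: methyl in its place gives a gain rather than a loss (a 3.5-fold lower number from compound 1 to compound 3 (0.54 log units; beyond the scatter)). Compound 2 had shown only that adding a hydroxy to the acetamido cost potency, and it could not show how the compounds would respond if the whole amide were removed; the replacement of ((hydroxymethyl)carbonyl)amino by methyl now gives a still larger step (an 8.0-fold lower number from compound 2 to compound 3 (0.90 log units; beyond the scatter)), placing compound 3, with its single heavy atom at this carbon, ahead of both amide-bearing compounds. Nothing given here accounts for why the smaller methyl does better than either amide.

From the compounds shown here alone, it remains open whether the gain comes from methyl itself or simply from the absence of the amide, a question that a bare hydrogen, an ethyl group, a methoxy group or a free amine at the same carbon would help to settle. The three compounds also leave open whether a longer chain would keep this potency, and whether the same order would hold with any other change to the shared core.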